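Amide nitrogen substitution in a chlorophenyl ether pyrazole series

The source may hold more compounds than are shown below. What is called first, only, known or untested is meant among the compounds shown, and "the series" means these compounds.

Compound 1 `Cc1cc(C(N)=O)nn1Cc1cc(Cl)ccc1OCc1ccccc1` gives 126 nM in an assay on CHO-K1 cells for displacement of a labelled ligand from prostaglandin E2 receptor EP1 subtype (Homo sapiens); a higher number here means a weaker inhibitor, a lower number a stronger inhibitor. Compound 2 `Cc1cc(C(N)=O)nn1Cc1cc(Cl)ccc1OCC(C)C` gives 126 nM in this assay. The step of no change at the digits printed from compound 1 to compound 2 (within the scatter) shows that the ether side tolerates this exchange without any shift. For the measured compounds named here, compound 2 therefore stands level with compound 1, the only other measured member of the series.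

Compound 3 `Cc1cc(C(=O)NN2CCCCC2)nn1Cc1cc(Cl)ccc1OCC(C)C` has not yet been measured. It differs from compound 2 by the change (piperidin-1-yl in place of hydrogen on an amide-type nitrogen). Going by the values given here, the single measured step, from compound 1 to compound 2, concerns the ether side only and says nothing about the amide nitrogen, so no direct precedent exists for this change. The expectation is that compound 3 shows a step of a 2.0-fold higher number from compound 2 to compound 3 (0.30 log units; within the scatter) in this assay, with the direction uncertain. For compound 3 the estimated value is 250 nM, in the range 60 nM to 1200 nM.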

Compound 3, half-maximal inhibitory concentration: 200 nM
Beside the measured number, compound 3's estimate is 1.3-fold (0.10 log units) above it; the measured number falls inside the stated range.
By their numbers in this assay, from the lowest: compounds 1, 2 and 3 (each within the scatter of the next).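

At the amide-type nitrogen, piperidin-1-yl in place of hydrogen gives a 1.6-fold higher number from compound 2 to compound 3 (0.20 log units; within the scatter) in this assay. For the compounds shown here, the earlier compounds varied only the ether side, so this is the first reading at this nitrogen: a substituent of 6 heavy atoms, including one six-membered non-aromatic ring, can stand there with the value still within the scatter of the unsubstituted carbamoyl compound. No measurement here accounts for this result or connects it to any property of the group.

The compounds shown leave open whether this holds for a nitrogen substituent attached through carbon, such as methyl or cyclohexyl, or for an open-chain dimethylamino group in place of piperidin-1-yl. They also leave open whether piperidin-1-yl gives a similar step when the ether side carries the phenyl group of compound 1.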